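Ethynyl to vinyl: the step from compound 3 to compound 4

The compounds below may be only part of what the source reports. "The series", "measured", "known", "first", "only" and "open" are said of these compounds alone.

Measured in a functional assay on SK-MEL-28 cells (Homo sapiens) for inhibition, read by colorimetric assay and MTT assay, with a stated time of 72 h; on this read-out higher numbers stand for weaker inhibition and lower numbers for stronger inhibition 
- compound 1 `Cn1c2cnc1OCCCCCCCCCCOc1ccccc1-2` gives 31000 nM 
- compound 2 `C=CCCCCOc1ccccc1-c1cnc(OCCCCC=C)n1C` gives 5000 nM 
- compound 3 `C#CCCCCOc1ncc(-c2ccccc2OC)n1C` gives 38000 nM 

Compound 3 stands within the scatter of compound 1, and compound 2 lies beyond the scatter on the lower side of it. Compound 4 `C=CCCCCOc1ncc(-c2ccccc2OC)n1C` is not yet measured. It differs from compound 3 thus: vinyl in place of ethynyl on a saturated chain carbon, four bonds along the chain from an oxygen on an aromatic ring, vinyl in place of ethynyl on a saturated chain carbon. Among the measured compounds shown here, no measured pair isolates this change. Compound 2 at 5000 nM also ends in vinyl but differs in more than that, so only a modest shift towards lower numbers in this assay is expected, possibly none beyond the scatter. The expected step is a 1.7-fold lower number from compound 3 to compound 4 (0.24 log units; within the scatter) in this estimate. For compound 4 the estimated value is 22000 nM, with an expected range of 9000 nM to 50000 nM.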

Compound 4, half-maximal inhibitory concentration: 13000 nM
The estimate for compound 4 lay 1.7-fold (0.23 log units) above the measured number, within the range that was stated.
By their numbers in this assay, from the lowest: compound 2; then compound 4; then compounds 1 and 3 (each within the scatter of the next).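

In this assay, among the compounds shown here, vinyl in place of ethynyl on a saturated chain carbon, four bonds along the chain from an oxygen on an aromatic ring, gives a 2.9-fold lower number from compound 3 to compound 4 (0.47 log units; beyond the scatter) and is the first isolated reading of this change. Hydrogen in place of pent-4-en-1-yl on a saturated chain carbon bound to an oxygen on an aromatic ring gives a 2.6-fold higher number from compound 2 to compound 4 (0.41 log units; beyond the scatter), so this second chain also registers in the read-out. Nothing available explains either step.

From the compounds shown here alone, whether an amine or a carboxylic acid in place of vinyl would shift the number remains open, as does the effect of a longer chain ending in vinyl.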